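The compounds below may be only part of what the source reports. "The series", "measured", "known", "first", "only" and "open" are said of these compounds alone.

Three compounds have been measured in a functional assay on CHO cells with adenosine receptor A1 (Homo sapiens) as the target, read by cAMP accumulation and immunoassay, with a stated time of 6 min, tested at 0.1 uM; on this read-out lower numbers stand for a stronger effect and higher numbers for a weaker effect at the one concentration tested:

Compound 1, `CC(C)N1CCN(Cc2csc(N)c2C(=O)c2ccc(Cl)cc2)CC1`, gives 3.6%.
Compound 2, `Nc1scc(CN2CCN(c3ccc(OC(F)(F)F)cc3)CC2)c1C(=O)c1ccc(Cl)cc1`, gives -13%.
Compound 3, `Nc1scc(CN2CCN(c3ccc(C(F)(F)F)cc3)CC2)c1C(=O)c1cccc(C(F)(F)F)c1`, gives -11%.

Compound 2 stands lowest of these three numbers. Its nearest neighbour is compound 3, whose value lies within the scatter of repeated measurements, so the two cannot be told apart; compound 1 lies further away, beyond the scatter. Among the measured compounds shown here, the one measured step that reaches compound 2 is a number 16.6 percentage points lower from compound 1 to compound 2 (beyond the scatter), a modest shift that accompanies the change from isopropyl to 4-(trifluoromethoxy)phenyl on the ring nitrogen.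

The next compound, compound 4, `Nc1scc(CN2CCN(c3ccccc3Cl)CC2)c1C(=O)c1ccc(Cl)cc1`, has not yet been measured in this assay. It differs from compound 2 in one place: 2-chlorophenyl in place of 4-(trifluoromethoxy)phenyl on an amine nitrogen in a ring. For the measured compounds named here, this is a swap of one aromatic group for another on the same ring nitrogen, and no measured step covers such a swap directly. What the data do show is that both compounds carrying an aromatic group on that nitrogen, compound 2 and compound 3, sit within the scatter of each other, whereas compound 1 with isopropyl sits higher. On that basis compound 4 is expected to stay near compound 2, with a step of a number 5 percentage points higher from compound 2 to compound 4 (within the scatter) that is expected to lie within the scatter. The estimate for compound 4 is -8%, with a likely range from -22% to 6%.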

Compound 4, a percentage reported as activity, at one concentration (the size of the read-out at that concentration, not a potency): 2%
Compound 4: the middle estimate sits 10 percentage points below what was measured, and the stated range covers the measured number.
By their numbers in this assay, from the lowest: compounds 2 and 3 (each within the scatter of the next); then compounds 4 and 1 (each within the scatter of the next).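

In this assay, the swap on the ring nitrogen from 4-(trifluoromethoxy)phenyl to 2-chlorophenyl gives a number 15 percentage points higher from compound 2 to compound 4 (beyond the scatter) and so shows that two aromatic groups at this position need not read alike. The swap from isopropyl to 2-chlorophenyl gives a number 1.6 percentage points lower from compound 1 to compound 4 (within the scatter) and so shows that an aromatic group on this nitrogen does not by itself bring the lower number seen for compound 2; what matters here is which aromatic group is attached. Nothing available explains why these two aromatic groups differ.

The change from compound 2 to compound 4 alters both the group carried by the benzene ring and where it sits, so the compounds shown cannot separate these two effects; a 4-chlorophenyl group on the same nitrogen would keep the chlorine while changing its place, and a plain phenyl group would show the ring with nothing on it. Each number also comes from a single concentration, so it leaves open how these compounds would compare across a range of concentrations.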